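The source may hold more compounds than are shown below. What is called first, only, known or untested is meant among the compounds shown, and "the series" means these compounds.

Measured compounds:
- Compound 1 `Cc1ccc(O)c(/C=N/NC(=S)N/N=C2\C(=O)Nc3ccc(C)cc32)c1`: in a functional assay on COS-7 cells (Chlorocebus aethiops) for inhibition, read by MTT assay (on this read-out lower numbers stand for stronger inhibition and higher numbers for weaker inhibition), compound 1 gives > 50000 nM, which is a limit of the assay.
- Compound 2 `Cc1ccc2c(c1)/C(=N/NC(=S)N/N=C/c1c(Cl)cccc1Cl)C(=O)N2`: in this assay compound 2 gives 3870 nM.
- Compound 3 `O=C1Nc2ccc(Br)cc2/C1=N/NC(=S)N/N=C/c1ccc2ccccc2c1`: in this assay compound 3 gives > 50000 nM, which is a limit of the assay.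

Compound 3 therefore stands at the limit of > 50000 nM in this assay, at which 2 of the 3 values shown sit, so no number is known for it, only a ceiling. Compound 4 `Cc1ccc2c(c1)/C(=N/NC(=S)N/N=C/c1ccc3ccccc3c1)C(=O)N2` differs from compound 3 in one place: methyl in place of bromo on an aromatic carbon. Among the compounds with values here, the only measured step, an at least 12-fold lower number from compound 1 to compound 2 (1.11 log units; beyond the scatter), concerns the other end of the shared core, so it does not bear directly on this exchange. What the remaining pair shows is that compound 1, which already carries the methyl that enters here, sits at the same limit as compound 3, while compound 2, with the same methyl, gives a number. Whether the bromo-to-methyl exchange alone moves the read-out beyond the scatter cannot be read from these data, and the step from compound 3 to compound 4 in this assay is expected to be small or none, an at least 1.2-fold lower number from compound 3 to compound 4 (0.09 log units; that floor lies within the scatter). Compound 4 is accordingly estimated at 40000 nM, with a range from 8000 nM to 200000 nM, and a real chance that only a limit is reported again.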

Compound 4, half-maximal inhibitory concentration: > 50000 nM
Compound 4: only a limit was reported; the forecaster's own chance of this, stated with the estimate: 60%; middle value at least 1.2-fold (0.09 log units) away from the limit.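

Compound 3 and compound 4 both end at a limit of the assay, so no step can be read between them. Both stop at the same point: the limit of > 50000 nM in this assay, at which 3 of the 4 values shown sit. The compounds shown leave open whether methyl in place of bromo on an aromatic carbon changes the read-out in this assay at all.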